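From 3-methylbenzyl to 4-methylbenzyl at the assay limit

The source may report more compounds than this note shows. Statements on the series, on what has been measured and on what is new or still open speak of the compounds shown alone.

In a functional assay on SGC-7901 cells (Homo sapiens) for cytotoxicity, read by MTT assay, with a stated time of 48 h (a higher number here means a weaker inhibitor, a lower number a stronger inhibitor), compound 1 (`O=c1ccoc2cc(OCc3cn(Cc4ccccc4)nn3)ccc12`) gives > 100000 nM as a limit of the assay and not a number. Compound 2 (`Cc1cccc(Cn2cc(COc3ccc4c(=O)ccoc4c3)nn2)c1`) gives > 100000 nM as a limit too. Compound 2 therefore has no number of its own and stands at the limit of > 100000 nM in this assay, at which 2 of the 2 values shown sit, in the data so far.

Compound 3 (`Cc1ccc(Cn2cc(COc3ccc4c(=O)ccoc4c3)nn2)cc1`) is reached by one change (4-methylphenyl in place of 3-methylphenyl on a saturated chain carbon bound to an aromatic nitrogen), with 4-methylphenyl in place of 3-methylphenyl on a saturated chain carbon bound to an aromatic nitrogen. Within the data shown here, the one measured step that bears on this is a step that the two limits leave unreadable from compound 1 to compound 2 and it gives no size to carry over. That step also concerns a different change, methyl in place of hydrogen on an aromatic carbon. No direction can be read from it, so no shift beyond the scatter is expected in this assay and another limit is the likeliest report. The estimated move is a number no higher from compound 2 to compound 3 (the limit leaves the size open) and nothing larger is expected. For compound 3 the estimated value is 100000 nM with an expected range of 30000 nM to 150000 nM around it.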

Compound 3, half-maximal inhibitory concentration: > 100000 nM
Compound 3 gave a limit, no number (the forecaster's own chance of this, stated with the estimate: 70%); the middle value lies on the limit itself.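

No step can be read from compound 2 to compound 3 or from compound 1 to compound 3, since in this assay each compound gives a limit of the assay and not a number: the limit of > 100000 nM in this assay, at which 3 of the 3 values shown sit.

The compounds shown leave open whether 3-methylbenzyl and 4-methylbenzyl differ at all in this assay, and how far either lies from compound 1.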